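The compounds below may be only part of what the source reports. "The series", "measured", "known", "first", "only" and "open" are said of these compounds alone.

Measured compounds:
compound 1, `CC(=O)Nc1cccc(Cn2cc(-c3ccc4cn[nH]c4c3)ccc2=O)c1`, in an assay for inhibition of MAP kinase-interacting serine/threonine-protein kinase 2 (Homo sapiens), read by luminescence and ADP-Glo, with a stated time of 2 h (on this read-out lower numbers stand for stronger inhibition and higher numbers for weaker inhibition), gives 43 nM.
compound 2, `O=c1ccc(-c2ccc3cn[nH]c3c2)cn1Cc1cccc(C(F)(F)F)c1`, in this assay gives 32 nM.
compound 3, `O=c1ccc(-c2ccc3cn[nH]c3c2)cn1Cc1cccc(F)c1`, in this assay gives 38 nM.

Compound 3 stands second highest of the three numbers in this assay, yet all three sit within the scatter of one another: a 1.1-fold lower number from compound 1 to compound 3 (0.05 log units; within the scatter), a 1.3-fold lower number from compound 1 to compound 2 (0.13 log units; within the scatter), and a 1.2-fold higher number from compound 2 to compound 3 (0.07 log units; within the scatter). The next compound, compound 4, is `O=c1ccc(-c2ccc3cn[nH]c3c2)cn1Cc1ccc(Cl)c(Cl)c1`; relative to compound 3 the change is 3,4-dichlorophenyl in place of 3-fluorophenyl on a saturated chain carbon bound to an aromatic nitrogen. Among the measured compounds shown here, the steps that bear on this change are the three measured exchanges of the group on that same phenyl ring, and each of them stayed within the scatter. For the measured compounds named here, none of them placed two substituents on the ring, and none used chlorine, so the pair of chlorines in compound 4 has no direct precedent here. Since every exchange at this ring so far left the number unchanged within the scatter, compound 4 is expected to show no step beyond the scatter in this assay, an estimated 1.1-fold lower number from compound 3 to compound 4 (0.04 log units; within the scatter). Compound 4 is therefore estimated at 35 nM, within a range from 15 nM to 90 nM.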

Compound 4, half-maximal inhibitory concentration: 97 nM
For compound 4 the middle estimate is 2.8-fold (0.44 log units) below the measured one, outside the stated range (above it).
By their numbers in this assay, from the lowest: compounds 2, 3 and 1 (each within the scatter of the next); then compound 4.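

In this assay, among the compounds shown here, 3,4-dichlorophenyl in place of 3-fluorophenyl gives a 2.6-fold higher number from compound 3 to compound 4 (0.41 log units; beyond the scatter), the first step at this position that lies beyond the scatter. The group on the saturated chain carbon bound to an aromatic nitrogen therefore does not tolerate every exchange: the earlier exchanges among acetamido, trifluoromethyl and fluoro on the phenyl ring all stayed within the scatter, whereas this one moves the number modestly towards weaker inhibition. Nothing available here accounts for this step.

The compounds shown leave open whether the step goes with chlorine itself or with the presence of two substituents on the ring, a question that a phenyl with one chlorine or with two fluorines would address. On these data alone, how an amine or a carboxylic acid on this ring would read in this assay also remains open.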